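Swapping a pyrrole for a methoxyphenyl in an acrylamide

A few compounds are considered here, and "the series" means these few. Any claim that something is new, unique, unknown or untested is made for them only; others in the source may bear on it.

Measured compounds:
compound 1, `N#C/C(=C\c1ccc([N+](=O)[O-])cc1)C(=O)c1c[nH]c2ccccc12`: 35000 nM
compound 2, `N#C/C(=C\c1ccc[nH]1)C(=O)NCc1ccc(Cl)c(Cl)c1`: 6000 nM

In a functional assay on MCF7 cells (Homo sapiens) for inhibition, read by MTT assay, with a stated time of 72 h (a lower number here means a stronger inhibitor of growth, a higher number a weaker inhibitor of growth), compound 2 gives 6000 nM, the lower of the two numbers seen so far. Compound 1 gives 35000 nM in this assay, a gap that lies beyond the scatter. Compound 1 and compound 2 differ in several places at once, so nothing can be said about any single change between them.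

Compound 3, `COc1ccc(/C=C(\C#N)C(=O)NCc2ccc(Cl)c(Cl)c2)cc1`, has not been measured. It differs from compound 2 in one place: 4-methoxyphenyl in place of 1H-pyrrol-2-yl on a double-bonded chain carbon bound to a double-bonded chain carbon. Among the compounds with values here, no measured pair shows this change, so its effect is unknown here. Within the data shown here, the five-membered ring of compound 2 carries a hydrogen-bond donor that compound 3 lacks, and no measured compound tells what that loss does. A modest step toward a weaker inhibitor is expected, a 2.0-fold higher number from compound 2 to compound 3 (0.30 log units; within the scatter), with wide uncertainty. Compound 3 is estimated at 12000 nM in this assay, within a range from 3000 nM to 50000 nM.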

Compound 3, concentration for 50% growth inhibition: 45000 nM
Beside the measured number, compound 3's estimate is 3.8-fold (0.57 log units) below it; low and high end bracket the measured number.
By their numbers in this assay, from the lowest: compound 2; then compounds 1 and 3 (each within the scatter of the next).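

In this assay, placing 4-methoxyphenyl in place of 1H-pyrrol-2-yl on a double-bonded chain carbon bound to a double-bonded chain carbon gives a 7.5-fold higher number from compound 2 to compound 3 (0.88 log units; beyond the scatter) and so shows that this position responds to the group it carries, something the earlier pair, which differs in several places at once, could not show. The swap changes several things together: a five-membered aromatic ring with a hydrogen-bond donor leaves, and a six-membered aromatic ring of carbon only with a hydrogen-bond acceptor enters. No measurement here tells which of these differences accounts for the step.

On these data alone, whether ring size, the lost donor or the methoxy group matters most stays open. A plain phenyl or a 4-hydroxyphenyl at this place would help to separate these features.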